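Oxazolyl for Propynyl: A Step in Agonist Efficacy

The source may report more compounds than this note shows. Statements on the series, on what has been measured and on what is new or still open speak of the compounds shown alone.

Compounds measured so far:
- Compound 1, `COCCOc1ccc2c(c1)OC(COc1ccc(CCC(=O)O)c(F)c1)CC2`: 36%
- Compound 2, `O=C(O)CCc1ccc(OCC2COc3ccc(Cl)cc3O2)cc1F`: 50%
- Compound 3, `CC#CC(CC(=O)O)c1ccc(OCC2COc3ccc(Cl)cc3O2)cc1`: 104%

Of the compounds shown here, three have been measured in a functional assay on HEK293 cells for agonist activity at Free fatty acid receptor 1 (Homo sapiens), read by fluorescence and calcium flux, with a stated time of 10 min; a lower number here means a smaller maximal response, a higher number a larger maximal response. Compound 1 gives 36%, compound 2 gives 50%, and compound 3 gives 104%. Compound 3 stands highest of the three numbers; its nearest neighbour is compound 2, whose value lies lower by a gap beyond the scatter, and compound 1 lies lower still, again beyond the scatter. Compound 3 is therefore the compound with the largest maximal response among those measured.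

The next compound, compound 4, `O=C(O)CC(c1ccc(OCC2COc3ccc(Cl)cc3O2)cc1)c1cnco1`, has not yet been measured in this assay. It differs from compound 3 in one place: 1,3-oxazol-5-yl in place of prop-1-yn-1-yl on a saturated chain carbon bound to an aromatic carbon and a saturated chain carbon. The change sits on a saturated chain carbon bound to an aromatic carbon and a saturated chain carbon, while the rest of the molecule stays as in compound 3.

Among the compounds with values here, no step between two measured compounds shows this kind of change, so no measured step can anchor the expectation. Given that compound 3 gives 104%, compound 4 is expected to keep a large maximal response, with a step from compound 3 to compound 4 in this assay of a number 14 percentage points lower from compound 3 to compound 4 (beyond the scatter), a small decrease that may well fall within the scatter. For compound 4 the estimate is 90%, within a range from 65% to 115%.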

Compound 4, largest response reached (Emax), in percent of the reference or control that the assay uses: 63%
For compound 4 the middle estimate is 27 percentage points above the measured one; the whole stated range lies above it.
By their numbers in this assay, from the lowest: compound 1; then compound 2; then compound 4; then compound 3.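

On the saturated chain carbon bound to an aromatic carbon and a saturated chain carbon, exchanging prop-1-yn-1-yl for 1,3-oxazol-5-yl in this assay gives a number 41 percentage points lower from compound 3 to compound 4 (beyond the scatter), a large step. Within the data shown here, this is the first step between measured compounds that differ in one place, so it is the first direct evidence that the maximal response depends on the group at this carbon, although compound 4 still reaches 63% and the response is not lost. No measurement at hand bears on the reason for this step.

With a single exchange at this carbon, the compounds shown leave open how other groups there would behave, such as a plain hydrogen, a cyclopropyl, a phenyl or a 1,3-thiazol-5-yl, and whether prop-1-yn-1-yl stands out among them or 1,3-oxazol-5-yl does. They also leave open whether a step of this size would recur with a different group in place of the chloro substituent on the shared core, for example a methoxy or a nitrile.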